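From oxan-4-yl to 2-bromoethyl on a carbonyl carbon

A few compounds are considered here, and "the series" means these few. Any claim that something is new, unique, unknown or untested is made for them only; others in the source may bear on it.

Compound 1 `COc1ncc(-c2ccc3ncnc(N[C@H]4CCCN(C(=O)C(F)(F)F)C4)c3c2)cc1C#N`: 210 nM
Compound 2 `COc1ncc(-c2ccc3ncnc(N[C@H]4CCCN(C(=O)C5CCOCC5)C4)c3c2)cc1C#N`: 150 nM
Compound 3 `COc1ncc(-c2ccc3ncnc(N[C@H]4CCCN(C(=O)CCBr)C4)c3c2)cc1C#N`: not yet measured

Among the compounds with values here, in a functional assay on SU-DHL-6 cells (Homo sapiens) for antiproliferative activity, read by MTT assay (on this read-out higher numbers stand for weaker inhibition and lower numbers for stronger inhibition), compound 2 gives 150 nM, which lies within the scatter of compound 1, the only other compound measured. Compound 3 carries 2-bromoethyl in place of oxan-4-yl on a carbonyl carbon. Within the data shown here, one measured step bears on this, at the same place: a 1.4-fold lower number from compound 1 to compound 2 (0.15 log units; within the scatter). Among the measured compounds shown here, with only that step to go on, nothing beyond the scatter is expected in this assay, and the expected result is a 1.1-fold higher number from compound 2 to compound 3 (0.05 log units; within the scatter). For compound 3 the estimated value is 170 nM, within an expected range of 60 nM to 500 nM.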

Compound 3, half-maximal inhibitory concentration: 15 nM
Beside the measured number, compound 3's estimate is 11-fold (1.05 log units) above it; the measured number lies below the stated range.
By their numbers in this assay, from the lowest: compound 3; then compounds 2 and 1 (each within the scatter of the next).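

The position on the carbonyl carbon proves far from indifferent in this assay: the earlier swap of trifluoromethyl for oxan-4-yl stayed within the scatter, whereas 2-bromoethyl brings a 10-fold lower number from compound 2 to compound 3 (1.00 log units; beyond the scatter) and also a 14-fold lower number from compound 1 to compound 3 (1.15 log units; beyond the scatter). Both steps lie beyond the scatter, so among these three compounds only this acyl group separates from the others. No measurement shown here accounts for the drop. Still open, from the compounds shown here alone, is whether the change follows the bromine or the chain, which ethyl, 2-chloroethyl or 3-bromopropyl on the same carbonyl carbon would separate.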